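A dichlorobenzyl isomer of compound 2

The compounds below may be only part of what the source reports. "The series", "measured", "known", "first", "only" and "open" are said of these compounds alone.

compound 1 (`Cc1ccc(C(=O)Nc2sc3c(c2C(N)=O)CCN(Cc2ccc(Cl)cc2Cl)C3)cc1`): 25500 nM
compound 2 (`NC(=O)c1c(NC(=O)c2ccccc2F)sc2c1CCN(Cc1c(Cl)cccc1Cl)C2`): 7430 nM

In a functional assay on MKN-74 cells (Homo sapiens) for antiproliferative activity, with a stated time of 24 h (on this read-out lower numbers stand for stronger inhibition and higher numbers for weaker inhibition), compound 2 stands at 7430 nM as the lower of the two numbers, and compound 1 at 25500 nM lies higher by more than the usual scatter of such measurements.

Compound 3 (`NC(=O)c1c(NC(=O)c2ccccc2F)sc2c1CCN(Cc1ccc(Cl)cc1Cl)C2`) has the same atoms as compound 2, joined differently: 2,4-dichlorophenyl in place of 2,6-dichlorophenyl on a saturated chain carbon bound to an amine nitrogen in a ring with 2,4-dichlorophenyl in place of 2,6-dichlorophenyl on a saturated chain carbon bound to an amine nitrogen in a ring.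

Among the compounds with values here, no pair of measured compounds shows this change alone. Compound 1 at 25500 nM carries the 2,4-dichlorobenzyl group that compound 3 gains, but it differs from compound 3 elsewhere as well, so it offers only a weak hint towards a higher number. A small rise, towards weaker inhibition, is therefore expected in this assay. The expected change is a 1.3-fold higher number from compound 2 to compound 3 (0.13 log units; within the scatter) and should stay within the scatter. For compound 3 the estimated value is 10000 nM with an expected range from 3500 nM to 28000 nM in this assay for repeated measurements.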

Compound 3, half-maximal inhibitory concentration: 9610 nM
Compound 3: middle estimate off by 1.0-fold (0.02 log units), on the high side; low and high end bracket the measured number.
By their numbers in this assay, from the lowest: compounds 2 and 3 (each within the scatter of the next); then compound 1.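

In this assay, the dichlorobenzyl group on the ring amine nitrogen can now be read on its own: 2,4-dichlorophenyl in place of 2,6-dichlorophenyl gives a 1.3-fold higher number from compound 2 to compound 3 (0.11 log units; within the scatter) and so does not separate the two chlorine patterns on this read-out. Compound 3 also provides a single-place comparison at the carbonyl carbon, where 2-fluorophenyl in place of 4-methylphenyl gives a 2.7-fold lower number from compound 1 to compound 3 (0.42 log units; beyond the scatter) with the 2,4-dichlorobenzyl group held constant, so among these compounds a change at the carbonyl carbon, not the change in chlorine pattern, goes beyond the scatter. Nothing available explains either step.

The compounds shown leave open whether a different group on the saturated chain carbon, such as a pyridine ring or a methoxyphenyl group, would shift the number beyond the scatter. They also leave open how other groups on the carbonyl carbon, such as a cyclohexyl or thiophene ring, would compare with 2-fluorophenyl, and whether the step from 4-methylphenyl to 2-fluorophenyl would carry over to the 2,6-dichlorobenzyl series.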